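A few compounds are considered here, and "the series" means these few. Any claim that something is new, unique, unknown or untested is made for them only; others in the source may bear on it.

Measured so far in a physicochemical assay for lipophilicity, at pH 7.4; on this read-out lower numbers stand for lower lipophilicity and higher numbers for higher lipophilicity:

- compound 1 `CCc1ccc(N(CC(C)C)S(=O)(=O)c2ccc3c(c2)C(=O)CC(CC2CCOCC2)O3)cc1`: 4.53
- compound 2 `Cc1ccc(N(C2CCC2)S(=O)(=O)c2ccc3c(c2)C(=O)CC(C2CCOCC2)O3)c(C)c1`: 3.86

Among the measured compounds shown here, compound 1 holds the higher of the two numbers so far; compound 2 sits lower by a gap that lies beyond the usual scatter. For the measured compounds named here, no pair of measured compounds differs in only one place, so no single step can be read off from the two values; they show only that the two distinct substitution patterns on the shared core sit apart in this assay.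

Compound 3 `CCc1ccc(N(CC(C)C)S(=O)(=O)c2ccc3c(c2)C(=O)CC(C2CCOCC2)O3)cc1` is the next compound to be measured. Relative to compound 1 it differs in one place only: oxan-4-yl in place of (oxan-4-yl)methyl on a saturated ring carbon. The entering group oxan-4-yl carries one heavy atom fewer than the leaving (oxan-4-yl)methyl, the ring, its oxygen and the acceptor count being otherwise unchanged.

With nothing in the set to anchor this particular change, the expectation rests on compound 1, which gives 4.53 in this assay, and on the small size of the change. A small downward step a number 0.43 log units lower from compound 1 to compound 3 (beyond the scatter) is expected, close to or just beyond the scatter. Compound 3 is accordingly estimated at 4.1, with a range from 3.75 to 4.5.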

Compound 3, distribution coefficient: 4.21
Compound 3: the middle estimate sits 0.11 log units below what was measured; the range from low to high includes it.
By their numbers in this assay, from the lowest: compound 2; then compound 3; then compound 1.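

In this assay, the saturated ring carbon next to the ring oxygen now has its first read-out for a change in one place: oxan-4-yl in place of (oxan-4-yl)methyl gives a number 0.32 log units lower from compound 1 to compound 3 (beyond the scatter), a modest step. The two earlier compounds could not separate this position from the other differences between them, whereas this pair shows that the read-out responds to this position alone, with the heavy atom count going from 7 to 6 while the hydrogen-bond donor and acceptor counts stay the same. Nothing at hand gives a reason for the size or the direction of this step.

Going by these compounds, with a single pair at this position, it remains open whether the read-out keeps moving the same way along a series of chain lengths, for instance with a longer chain such as 2-(oxan-4-yl)ethyl, or how a piperidin-4-yl group, an amine, would compare with oxan-4-yl here. Among the compounds shown here, also open is whether a step of this size would hold with the other substitution pattern on the shared core, the one carried by compound 2.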